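Swapping Methoxy for Fluoro on Compound 2

The source may report more compounds than this note shows. Statements on the series, on what has been measured and on what is new or still open speak of the compounds shown alone.

Measured compounds in a functional assay on MCF7 cells (Homo sapiens) for antiproliferative activity, read by MTT assay, with a stated time of 48 h; a higher number here means a weaker inhibitor, a lower number a stronger inhibitor
Compound 1 `CC(=O)N1N=C(c2ccc3ccccc3c2)OC1c1ccccc1` gives 2.43 ug/mL
Compound 2 `COc1ccc(C2OC(c3ccc4ccccc4c3)=NN2C(C)=O)cc1` gives 7.35 ug/mL
Compound 3 `CC(=O)N1N=C(c2ccc3ccccc3c2)OC1c1ccccc1F` gives 3.44 ug/mL

Compound 2 has the highest number of the three in this assay and so is the weakest inhibitor among them. Compound 4 `CC(=O)N1N=C(c2ccc3ccccc3c2)OC1c1ccc(F)cc1` differs from it in one place (fluoro in place of methoxy on an aromatic carbon), with fluoro in place of methoxy on an aromatic carbon, para to a large group. Methoxy in place of hydrogen brought a modest rise (a 3.0-fold higher number from compound 1 to compound 2 (0.48 log units; beyond the scatter)), while fluoro in place of hydrogen stayed within the scatter (a 1.4-fold higher number from compound 1 to compound 3 (0.15 log units; within the scatter)). Changing 4-methoxyphenyl directly to 2-fluorophenyl brought a modest fall (a 2.1-fold lower number from compound 2 to compound 3 (0.33 log units; beyond the scatter)). Compound 3 carries 2-fluorophenyl, not the 4-fluorophenyl of compound 4, so this is only a guide. A modest step to a lower number is therefore expected (a 2.3-fold lower number from compound 2 to compound 4 (0.36 log units; beyond the scatter)). The expected value for compound 4 is 3.2 ug/mL (estimated range 1.6 ug/mL to 6.4 ug/mL).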

Compound 4, half-maximal inhibitory concentration: 3.02 ug/mL
Beside the measured number, compound 4's estimate is 1.1-fold (0.03 log units) above it; low and high end bracket the measured number.
By their numbers in this assay, from the lowest: compounds 1, 4 and 3 (each within the scatter of the next); then compound 2.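

Swapping methoxy directly for fluoro at this place lowers the number (a 2.4-fold lower number from compound 2 to compound 4 (0.39 log units; beyond the scatter)), so the rise seen with 4-methoxyphenyl does not appear with 4-fluorophenyl. Fluoro here stays level with hydrogen (a 1.2-fold higher number from compound 1 to compound 4 (0.09 log units; within the scatter)), and 2-fluorophenyl and 4-fluorophenyl cannot be told apart (a 1.1-fold lower number from compound 3 to compound 4 (0.06 log units; within the scatter)). Nothing available explains why methoxy and fluoro differ at this place.

Going by these compounds, it remains open how other groups at this place would read, such as an amine, a carboxylic acid or a longer chain like butoxy.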